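Trimming the alkyne chain by a methyl-to-hydrogen step

A few compounds are considered here, and "the series" means these few. Any claim that something is new, unique, unknown or untested is made for them only; others in the source may bear on it.

Compound 1 `CCc1cc(C)oc(=O)c1`: > 50000 nM
Compound 2 `CCCCCCC#Cc1cc(C)oc(=O)c1`: 3400 nM
Compound 3 `CCOCCc1cc(C)oc(=O)c1`: > 50000 nM

Among the compounds with values here, in a functional assay on A2780 cells (Homo sapiens) for inhibition (a higher number here means a weaker inhibitor, a lower number a stronger inhibitor), compound 2 gives the only number of the three. The value of compound 1 is a limit of the assay. The value of compound 3 is likewise a limit, and both sit at the limit of > 50000 nM in this assay, at which 2 of the 3 values shown sit. Within the data shown here, the one step between measured compounds, a step that the two limits leave unreadable from compound 1 to compound 3, therefore cannot be read. Compound 4 `CCCCCC#Cc1cc(C)oc(=O)c1` differs from compound 2 by hydrogen in place of methyl on a saturated chain carbon, five bonds along the chain from a triple-bonded carbon. Among the measured compounds shown here, no measured step speaks to such a change, so the expectation rests on compound 2 alone. The step of a 1.5-fold higher number from compound 2 to compound 4 (0.17 log units; within the scatter) is expected to stay close to the scatter. Compound 4 is estimated at 5000 nM, with a range from 1500 nM to 20000 nM.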

Compound 4, half-maximal inhibitory concentration: 2900 nM
Compound 4: the middle estimate sits 1.7-fold (0.24 log units) above what was measured; low and high end bracket the measured number.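

In this assay the change of methyl to hydrogen on a saturated chain carbon, five bonds along the chain from a triple-bonded carbon, gives a 1.2-fold lower number from compound 2 to compound 4 (0.07 log units; within the scatter) and so makes no readable difference. Within the data shown here, this is the first step here that can be read as a number, and it shows that the alkyne chain tolerates this one change at this position. On these data alone, whether a longer chain, or an amine in place of that methyl, would also be tolerated stays open. Nothing given about the compounds accounts for this result.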